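Isopropoxy in place of 3-chloropropoxy: toxicity outlook

This account rests on a few compounds, and the source may have more. Where it says the series, first, only, none or still open, it means among the compounds named here.

In a toxicity assay on Huh-7.5 cells (Homo sapiens) for inhibition, read by MTT assay, with a stated time of 96 h (on this read-out higher numbers stand for lower toxicity in this test and lower numbers for higher toxicity in this test), compound 3 `CN1CCN(Cc2ccc(NC(=O)c3ccc(OCCCCl)c([N+](=O)[O-])c3)cc2C(F)(F)F)CC1` gives 6800 nM and stands within the scatter of compound 2 `CC(C)Oc1ccc(C(=O)Nc2ccc(CN3CCN(C)CC3)c(C(F)(F)F)c2)cc1NC(=O)C(C)Br` at 8700 nM. Compound 1 `CN1CCN(Cc2ccc(NC(=O)c3ccc(OCCCCCCl)c([N+](=O)[O-])c3)cc2C(F)(F)F)CC1` gives 2140 nM. Compound 4 `CC(C)Oc1ccc(C(=O)Nc2ccc(CN3CCN(C)CC3)c(C(F)(F)F)c2)cc1[N+](=O)[O-]` has isopropyl in place of 3-chloropropyl on an oxygen on an aromatic ring. Among the measured compounds shown here, the one measured step on this chain is modest (a 3.2-fold higher number from compound 1 to compound 3 (0.50 log units; beyond the scatter)) and is not the change at hand. Compound 2 also carries isopropoxy, and its value (8700 nM) sits within the scatter of compound 3. No shift beyond the scatter is therefore expected in this assay for this change. The expected step stays small (a 1.3-fold higher number from compound 3 to compound 4 (0.10 log units; within the scatter)). Compound 4 is estimated at 8500 nM (range 3500 nM to 20000 nM).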

Compound 4, half-maximal cytotoxic concentration: 3500 nM
Estimate against measurement, compound 4: 2.4-fold (0.39 log units) above; the range from low to high includes it.
By their numbers in this assay, from the lowest: compounds 1, 4, 3 and 2 (each within the scatter of the next, the first and the last beyond it).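

In this assay the change on the oxygen gives a 1.9-fold lower number from compound 3 to compound 4 (0.29 log units; within the scatter) and so stays within the scatter, and the swap from 5-chloropentyl gives a 1.6-fold higher number from compound 1 to compound 4 (0.21 log units; within the scatter) and also stays within it. Among the compounds shown here, the exchange of nitro for ((1-bromoethyl)carbonyl)amino on an aromatic carbon gives a 2.5-fold lower number from compound 2 to compound 4 (0.40 log units; beyond the scatter) and is the only new step beyond the scatter. No evidence on hand bears on the cause of these steps. Open, on these data alone, is whether a chain ending in an amine or a carboxylic acid on the same oxygen would stay within the scatter of compound 4.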